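Swapping the pyrazole for fluorophenyl on a second core

The source may hold more compounds than are shown below. What is called first, only, known or untested is meant among the compounds shown, and "the series" means these compounds.

Compound 2 `CC(c1ccc2ncc(-c3cnn(C)c3)cc2c1)n1nnc2ncc(-c3ccncc3)nc21` gives 0.9 nM in a functional assay on NCI-H1993 cells (Homo sapiens) for inhibition, read by CCK-8 assay, with a stated time of 72 h; on this read-out lower numbers stand for stronger inhibition and higher numbers for weaker inhibition. Compound 1 `CC(c1ccc2ncc(-c3ccc(F)cc3)cc2c1)n1nnc2ncc(-c3ccncc3)nc21` differs from it by 4-fluorophenyl in place of 1-methyl-1H-pyrazol-4-yl on an aromatic carbon, and in this assay compound 1 gives 8.7 nM, a step of a 9.7-fold higher number from compound 2 to compound 1 (0.99 log units; beyond the scatter). Compound 3 `CC(c1c(F)cc2ncc(-c3cnn(C)c3)cc2c1F)n1nnc2ncc(-c3ccncc3)nc21` carries a different core; how the two cores differ is not broken down here. In this assay compound 3 gives 0.2 nM, the lowest of the three. Among the measured compounds shown here, compound 4 `CC(c1c(F)cc2ncc(-c3ccc(F)cc3)cc2c1F)n1nnc2ncc(-c3ccncc3)nc21` has not been measured; it differs from compound 3 by 4-fluorophenyl in place of 1-methyl-1H-pyrazol-4-yl on an aromatic carbon, the same change as the one from compound 2 to compound 1, made at the same place. A comparable weakening is expected, a step of a 9.5-fold higher number from compound 3 to compound 4 (0.98 log units; beyond the scatter), because the earlier step was a 9.7-fold higher number from compound 2 to compound 1 (0.99 log units; beyond the scatter). Compound 4 is therefore estimated at 1.9 nM, likely between 0.6 nM and 6 nM.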

Compound 4, half-maximal inhibitory concentration: 3.5 nM
Estimate against measurement, compound 4: 1.8-fold (0.27 log units) below, and the stated range covers the measured number.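

On the second core the same swap again weakens inhibition in this assay, with an 18-fold higher number from compound 3 to compound 4 (1.24 log units; beyond the scatter). The two steps point the same way and do not differ in size beyond what repeat measurements allow: the same change on two cores in this assay, a 9.7-fold higher number (0.99 log units; beyond the scatter) from compound 2 to compound 1 and an 18-fold higher number (1.24 log units; beyond the scatter) from compound 3 to compound 4, 1.8-fold (0.26 log units) apart, within the scatter of two such steps. The loss from replacing the pyrazole therefore carried over between these two cores, but two pairs make no general rule, and they do not show why the number rises.

The compounds shown leave open whether the step would hold on further cores. They also leave open how an amine, a carboxylic acid or a longer chain would read at this place in this assay.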